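Removing the aromatic methyl of compound 1

The source may hold more compounds than are shown below. What is called first, only, known or untested is meant among the compounds shown, and "the series" means these compounds.

Measured so far in a functional assay on CHO cells for agonist activity at Free fatty acid receptor 1 (Homo sapiens), read by FLIPR and calcium flux; on this read-out lower numbers stand for an effect already at smaller amounts and higher numbers for an effect only at larger amounts of compound:
compound 1 `CCOc1ccc(C)c(-c2cccc(COc3ccc(OCC(=O)O)c(F)c3)c2)c1` gives 220 nM
compound 2 `CCCOc1ccc(C)c(-c2cccc(COc3ccc(OCC(=O)O)c(F)c3)c2)c1` gives 610 nM
compound 3 `Cc1ccc(OCCC2CCCCC2)cc1-c1cccc(COc2ccc(OCC(=O)O)c(F)c2)c1` gives 520 nM

Compound 1 stands lowest of the three numbers in this assay. The measured steps concern the alkoxy chain only: a 2.8-fold higher number from compound 1 to compound 2 (0.44 log units; beyond the scatter) and a 2.4-fold higher number from compound 1 to compound 3 (0.37 log units; beyond the scatter), both modest, while a 1.2-fold lower number from compound 2 to compound 3 (0.07 log units; within the scatter).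

Compound 4 `CCOc1cccc(-c2cccc(COc3ccc(OCC(=O)O)c(F)c3)c2)c1` differs from compound 1 by hydrogen in place of methyl on an aromatic carbon. Going by the values given here, none of the measured steps touches this aromatic position, so they give no direct guide. With no comparison available, the expectation for compound 4 is kept near compound 1 with a wide range, leaning towards a somewhat higher number: expected step a 2.0-fold higher number from compound 1 to compound 4 (0.31 log units; beyond the scatter), giving an estimate for compound 4 of 450 nM (range 150 nM to 1500 nM).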

Compound 4, half-maximal effective concentration: 480 nM
Estimate against measurement, compound 4: 1.1-fold (0.03 log units) below; measured number inside the range.
By their numbers in this assay, from the lowest: compound 1; then compounds 4, 3 and 2 (each within the scatter of the next).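

In this assay, the change from 5-ethoxy-2-methylphenyl to 3-ethoxyphenyl gives a 2.2-fold higher number from compound 1 to compound 4 (0.34 log units; beyond the scatter). Going by these compounds alone, this is the first measured step outside the alkoxy chain, and it shows that the methyl on this aromatic carbon, ortho to a large group and para to an ethoxy group, goes with the lower number in this pair. Nothing measured bears on the origin of this step.

Open, on these data alone, is whether ethyl, chlorine or methoxy on this carbon would match the methyl. Also open, as far as these compounds go, is whether removing the methyl gives a similar step in compound 2 and compound 3, with their different chains.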